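The source may report more compounds than this note shows. Statements on the series, on what has been measured and on what is new or still open speak of the compounds shown alone.

Measured in a functional assay on A2780 cells (Homo sapiens) for antiproliferative activity, read by CellTiter-Glo, with a stated time of 4 days; a higher number here means a weaker inhibitor, a lower number a stronger inhibitor:
Compound 1 `O=C(NCc1cccnc1)Nc1ccc(CN2C(=O)c3ccccc3C2=O)cc1`: 100 nM
Compound 2 `O=C(NCc1cccnc1)Nc1ccc(CNC(=O)c2ccc(CN3CCNCC3)cc2)cc1`: 8 nM
Compound 3 `CCC(=O)NCc1ccc(NC(=O)[C@H]2C[C@@H]2c2cccnc2)cc1`: 405 nM

Compound 3 has the highest of these three numbers, which makes it the weakest inhibitor of the group. Compound 1 is its nearest neighbour and compound 2 its furthest, and both gaps lie beyond the usual scatter.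

Compound 4 `COCC(=O)N[C@@H](C)c1ccc(NC(=O)[C@H]2C[C@@H]2c2cccnc2)cc1` keeps the shared core of compound 3 but replaces the (propanoylamino)methyl group, on an aromatic carbon para to a large group: a group of 8 heavy atoms (5 carbon, 1 nitrogen, 2 oxygen; no ring) in place of a group of 6 heavy atoms (4 carbon, 1 nitrogen, 1 oxygen; no ring), on an aromatic carbon.

Among the compounds with values here, no two measured compounds differ in only one place, so the data give no direct measure of what such a swap does. The expectation is therefore loose. Compound 3, at 405 nM, sits at the top of the measured values, so a moderate step toward a lower number in this assay is expected, though it may barely clear the scatter. The estimate means an expected 2.0-fold lower number from compound 3 to compound 4 (0.31 log units; beyond the scatter). The estimated value for compound 4 is 200 nM, within an expected range of 50 nM to 800 nM.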

Compound 4, half-maximal inhibitory concentration: 30 nM
Compound 4: the middle estimate sits 6.7-fold (0.82 log units) above what was measured, outside the stated range (below it).
By their numbers in this assay, from the lowest: compound 2; then compound 4; then compound 1; then compound 3.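

In this assay the aromatic carbon para to a large group proves highly sensitive to what it carries: replacing the (propanoylamino)methyl group with the larger group gives a 14-fold lower number from compound 3 to compound 4 (1.13 log units; beyond the scatter) with the rest of the molecule unchanged. Within the data shown here, this is the first direct measure of a change in one place in this set, and it shows that the group at this position can shift the result well beyond the scatter. The entering group differs from the old one in size, in its hydrogen-bond acceptors and in its defined stereocentre, and nothing available explains the step or ties it to any one of these features.

The compounds shown leave open whether the added methyl branch or the methoxy end carries the step, and whether the opposite stereocentre would match it. They also leave open how an amine or a carboxylic acid at the end of this chain would behave.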